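Aryl variation on the shared core: formyl replaces methyl

This account rests on a few compounds, and the source may have more. Where it says the series, first, only, none or still open, it means among the compounds named here.

Of the compounds shown here, three have been measured in a functional assay on LOX IMVI cells (Homo sapiens) for inhibition, read by sulforhodamine B assay, with a stated time of 48 h, tested at 10 uM; on this read-out lower numbers stand for less inhibition and higher numbers for more inhibition at the one concentration tested (going by the name of the read-out). Compound 1 `O=Cc1ccc(-c2cn3ccnc3c(-c3ccc4ncn(C5CCCCC5)c4c3)n2)cc1` gives 46.9% and compound 2 `CCc1ccc(-c2cn3ccnc3c(-c3ccc4ncn(Cc5ccccc5)c4c3)n2)cc1` gives 50.2%. Compound 3 `Cc1cccc(-c2cn3ccnc3c(-c3ccc4ncn(Cc5ccccc5)c4c3)n2)c1` stands lowest of the three with 14.8%; it lies beyond the scatter under both compound 1 and compound 2. Going by the values given here, the only single-point step recorded is a number 35.4 percentage points lower from compound 2 to compound 3 (beyond the scatter), a large loss on exchanging the aryl group.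

Compound 4 `O=Cc1ccc(-c2cn3ccnc3c(-c3ccc4ncn(Cc5ccccc5)c4c3)n2)cc1` is not yet measured in this assay. It differs from compound 3 by 4-formylphenyl in place of 3-methylphenyl on an aromatic carbon. The step from compound 2 to compound 3 bears on this change only indirectly, since it shows that the aryl group at this position can move this assay by a large amount. Compound 1 also carries a 4-formylphenyl group, on a core that otherwise differs from compound 4 only in the group on the ring nitrogen, and it gives a value well above compound 3. Among the compounds with values here, no step is recorded for that pair, so it serves as a guide only.

Compound 4 is therefore expected to gain, with an estimated a number 30.2 percentage points higher from compound 3 to compound 4 (beyond the scatter). The estimate for compound 4 in this assay is 45%, within a range of 25% to 65%.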

Compound 4, a percentage reported as inhibition, at one concentration (the size of the read-out at that concentration, not a potency): 46.9%
For compound 4 the middle estimate is 1.9 percentage points below the measured one; the measured number falls inside the stated range.
By their numbers in this assay, from the lowest: compound 3; then compounds 1, 4 and 2 (each within the scatter of the next).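

In this assay the change itself now has a recorded step: 4-formylphenyl in place of 3-methylphenyl gives a number 32.1 percentage points higher from compound 3 to compound 4 (beyond the scatter) and shows that the low number of compound 3 does not hold for every aryl group at this position on the shared core. Formyl in place of ethyl on the same phenyl ring gives a number 3.3 percentage points lower from compound 2 to compound 4 (within the scatter) so 4-formylphenyl and 4-ethylphenyl are not told apart in this read-out. With 4-formylphenyl in place, benzyl in place of cyclohexyl on the ring nitrogen gives no change at the digits printed from compound 1 to compound 4 (within the scatter) so these two nitrogen groups are not told apart either. The data offer no measurement that explains the large step.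

The compounds shown leave open whether the low number of compound 3 goes with methyl itself or with where the group sits on the phenyl ring, a question that 4-methylphenyl and 3-formylphenyl would bear on. Also open, going by these compounds, is how this position would read with a 4-aminophenyl or 4-carboxyphenyl group, or with a chain longer than ethyl.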